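Working notes on the series, toward compound 4

The source may report more compounds than this note shows. Statements on the series, on what has been measured and on what is new or still open speak of the compounds shown alone.

Compound 1 `Cc1ccnc(Nc2cc(N3CCC[C@@H](N)C3)nc3ccnn23)c1` gives > 100000 nM in an assay on isolated protein for inhibition of Dipeptidyl peptidase 9 (Homo sapiens) (on this read-out higher numbers stand for weaker inhibition and lower numbers for stronger inhibition), which is a limit of the assay and not a number.
Compound 2 `N[C@@H]1CCCN(c2cc(Nc3ccccc3Cl)n3nccc3n2)C1` gives > 100000 nM in this assay, again a limit of the assay.
Compound 3 `N[C@@H]1CCCN(c2cc(NCc3ccc(Cl)cc3Cl)n3nccc3n2)C1` gives > 100000 nM in this assay, also a limit of the assay.

Compound 3 therefore stands where the other two stand, at the limit, and nothing separates it from them on the numbers shown. Among the measured compounds shown here, the only step between measured compounds that differ in one place, a step that the two limits leave unreadable from compound 1 to compound 2, is unreadable, since both ends sit at the limit; the evidence is summed up by the limit of > 100000 nM in this assay, at which 3 of the 3 values shown sit.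

Compound 4 `N[C@@H]1CCCN(c2cc(NCc3ccccc3)n3nccc3n2)C1` differs from compound 3 by phenyl in place of 2,4-dichlorophenyl on a saturated chain carbon bound to a nitrogen on an aromatic ring. For the measured compounds named here, no measured step touches this position, so the size of the step from compound 3 to compound 4 in this assay cannot be read from the shared core's record; the whole series so far sits at the limit, and the expectation is that compound 4 stays there as well. Compound 4 is expected at 100000 nM, within 30000 nM to 300000 nM, because compound 3 gives > 100000 nM and no direction beyond the scatter can be argued. The estimated step of a number no higher from compound 3 to compound 4 (the limit leaves the size open) is thus expected to be none beyond the scatter.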

Compound 4, half-maximal inhibitory concentration: > 100000 nM
Compound 4: only a limit was reported; the forecaster's own chance of this, stated with the estimate: 85%; the middle value lies on the limit itself.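

No step can be read from compound 1, compound 2 or compound 3 to compound 4, since all of these compounds sit at the same limit, which is a limit of the assay and not a number: the limit of > 100000 nM in this assay, at which 4 of the 4 values shown sit.

The compounds shown leave open whether any group on the nitrogen on an aromatic ring can bring a value in this assay inside this limit.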